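Replacing an aromatic amide with a small acetyl group

The compounds below may be only part of what the source reports. "The series", "measured", "known", "first", "only" and "open" are said of these compounds alone.

Of the compounds shown here, three sharing one core have been measured in a functional assay on WI-38 VA13 cells (Homo sapiens) for cytotoxicity; a higher number here means that more compound is needed for the effect, a lower number that less compound is needed. Compound 1, `Cn1ncc([N+](=O)[O-])c1C(=O)Nc1ccc2nc(NC(=O)C3CCCCC3)sc2c1`, gives 0.026 ug/mL. Compound 2, `Cc1ccccc1C(=O)Nc1ccc2nc(NC(=O)C3CCCCC3)sc2c1`, gives 0.085 ug/mL, and compound 3, `N#Cc1ccc(C(=O)Nc2ccc3nc(NC(=O)C4CCCCC4)sc3c2)cc1`, gives 3.3 ug/mL. Compound 2 therefore stands second highest of the three numbers: the step of a 3.3-fold higher number from compound 1 to compound 2 (0.51 log units; beyond the scatter) is modest, while the step of a 39-fold higher number from compound 2 to compound 3 (1.59 log units; beyond the scatter) and the step of a 130-fold higher number from compound 1 to compound 3 (2.10 log units; beyond the scatter) are both large.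

Compound 4, `CC(=O)Nc1ccc2nc(NC(=O)C3CCCCC3)sc2c1`, is not yet measured. It differs from compound 2 by methyl in place of 2-methylphenyl on a carbonyl carbon. None of the three measured steps exchanges an aromatic group for a plain methyl; each swaps one ring for another, so the steps bear on the new change only by showing how much this position can matter. They range from modest to large, and the largest ones point towards higher numbers when the group on the carbonyl carbon is altered. Given that the step of a 39-fold higher number from compound 2 to compound 3 (1.59 log units; beyond the scatter) is large and the step of a 3.3-fold higher number from compound 1 to compound 2 (0.51 log units; beyond the scatter) is smaller, compound 4 is expected to show a step of a 12-fold higher number from compound 2 to compound 4 (1.07 log units; beyond the scatter) in this assay. The estimate for compound 4 is 1 ug/mL, with a likely range from 0.1 ug/mL to 10 ug/mL.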

Compound 4, half-maximal effective concentration: 2.7 ug/mL
Estimate against measurement, compound 4: 2.7-fold (0.43 log units) below; the measured number falls inside the stated range.
By their numbers in this assay, from the lowest: compound 1; then compound 2; then compounds 4 and 3 (each within the scatter of the next).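

Removing the ring has a large effect in this assay, with a 32-fold higher number from compound 2 to compound 4 (1.50 log units; beyond the scatter) and, on the same change from the other low-number compound, a 100-fold higher number from compound 1 to compound 4 (2.02 log units; beyond the scatter). Yet having a ring on this carbonyl carbon does not by itself give a low number: the plain methyl of compound 4 and the 4-cyanophenyl of compound 3 cannot be told apart, with a 1.2-fold lower number from compound 3 to compound 4 (0.09 log units; within the scatter) lying within the scatter. Among these four compounds, the low numbers therefore go only with 2-methylphenyl and 1-methyl-4-nitro-1H-pyrazol-5-yl, compound 3 is the exception to any rule that a ring is enough, and nothing available here explains this pattern.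

The compounds shown leave open whether an aromatic ring is needed at all, which a cyclohexyl group or a longer chain such as butyl on the same carbonyl carbon could test. They also leave open how an unsubstituted phenyl ring would compare, which would help separate the contribution of the ring from that of the methyl in compound 2 and the nitrile in compound 3.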